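Cytotoxicity notes: amide variation from compound 3 to compound 4

The compounds below may be only part of what the source reports. "The series", "measured", "known", "first", "only" and "open" are said of these compounds alone.

Measured so far in an ADME assay on BHK-21 cells (Mesocricetus auratus) for cytotoxicity, with a stated time of 3 days; a lower number here means that less compound is tolerated, a higher number that more compound is tolerated:
- compound 1 `CC(Sc1nnc(-c2ccncc2)s1)C(=O)NCc1ccc(Cl)cc1`: "not determined" (no result reported)
- compound 2 `O=C(CCSc1nnc(-c2ccncc2)s1)NCc1ccccc1`: 18700 nM
- compound 3 `CC(CSc1nnc(-c2ccncc2)s1)C(=O)Nc1c(Cl)cccc1Cl`: > 50000 nM

Among the compounds with values here, compound 3 is the one compound here that reaches the limit of this assay: its entry, > 50000 nM, is a limit and not a number, and it matches (the limit of > 50000 nM in this assay, at which 1 of the 3 values shown sits). Compound 1 has no result in this assay. Within the data shown here, the only single number in the set comes from compound 2, which gives 18700 nM in this assay.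

Compound 4 `CC(CSc1nnc(-c2ccncc2)s1)C(=O)NCc1ccccc1` is not yet measured. It differs from compound 3 in one place: benzyl in place of 2,6-dichlorophenyl on an amide-type nitrogen. The amide nitrogen of compound 4 thus carries the same benzyl group as that of compound 2, while the chain on the sulfur side remains that of compound 3.

Among the measured compounds shown here, no step between measured compounds is available, so the expectation rests on the two values shown. Compound 2, with a benzyl on the amide nitrogen, gives 18700 nM in this assay. Compound 3, by contrast, stands only at a limit of this assay. On that basis the step of an at least 2.0-fold lower number from compound 3 to compound 4 (0.30 log units; that floor lies within the scatter) is expected to point downward, though not by a large margin. Compound 4 is expected to give about 25000 nM in this assay, within a range from 8000 nM to 60000 nM, with a real chance that only a limit is reported.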

Compound 4, half-maximal cytotoxic concentration: > 50000 nM
Compound 4 ended at the assay's limit (the forecaster's own chance of this, stated with the estimate: 30%); middle value at least 2.0-fold (0.30 log units) from the limit.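

In this assay, benzyl in place of 2,6-dichlorophenyl on the amide-type nitrogen gives a second entry that is a limit and not a number, so the step between these two compounds cannot be read, and the only thing shared is where they stop: the limit of > 50000 nM in this assay, at which 2 of the 4 values shown sit.

The step that can be read concerns the chain: methyl in place of hydrogen on a saturated chain carbon bound to a carbonyl carbon and a saturated chain carbon gives an at least 2.6-fold higher number from compound 2 to compound 4 (0.42 log units; beyond the scatter). Within the data shown here, with benzyl held constant on the amide-type nitrogen, this is the first single change with a direction beyond the scatter, towards more compound tolerated, and its true size may be larger than the printed floor.

The compounds shown do not tell how far past the limit either compound 3 or compound 4 lies, or whether the same methyl has any effect when the amide-type nitrogen carries 2,6-dichlorophenyl. Going by these compounds, it also remains open whether a longer chain in place of that methyl, or an amine or a carboxylic acid on the benzyl group, would bring the read-out back to a single number.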